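This account rests on a few compounds, and the source may have more. Where it says the series, first, only, none or still open, it means among the compounds named here.

Compound 1 `CCC[C@H](CCn1cncn1)c1ccc(F)cc1`: 38.4 ug/mL
Compound 2 `CCC[C@H](CCn1cncn1)c1ccc(C)cc1`: 47.2 ug/mL
Compound 3 `CCC[C@H](CCn1cncn1)c1ccc(OC)cc1`: 59.3 ug/mL

In an ADME assay on RD cells (Homo sapiens) for cytotoxicity, read by MTT assay, with a stated time of 3 days (on this read-out lower numbers stand for higher toxicity in this test and higher numbers for lower toxicity in this test), compound 3 gives the highest of the three numbers, yet its gaps to compound 2 and to compound 1 both lie within the scatter, so the three measured compounds cannot be separated on this read-out. Compound 4 `CCCC[C@H](CCn1cncn1)c1ccc(OC)cc1` differs from compound 3 by methyl in place of hydrogen on a saturated chain carbon, four bonds along the chain from an aromatic carbon. Every measured step exchanges the group on the aromatic ring: a 1.2-fold higher number from compound 1 to compound 2 (0.09 log units; within the scatter), a 1.5-fold higher number from compound 1 to compound 3 (0.19 log units; within the scatter) and a 1.3-fold higher number from compound 2 to compound 3 (0.10 log units; within the scatter), all within the scatter. Among the measured compounds shown here, none of them alters the saturated chain, so no measured step bears directly on the change to compound 4, and no step beyond the scatter is expected in this assay. Compound 4 is therefore expected to give 55 ug/mL, with a range from 28 ug/mL to 110 ug/mL, which amounts to an expected 1.1-fold lower number from compound 3 to compound 4 (0.03 log units; within the scatter).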

Compound 4, half-maximal cytotoxic concentration: 28.3 ug/mL
Compound 4: middle estimate off by 1.9-fold (0.29 log units), on the high side, and the stated range covers the measured number.
By their numbers in this assay, from the lowest: compounds 4, 1, 2 and 3 (each within the scatter of the next, the first and the last beyond it).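

In this assay the saturated chain responds to a single added carbon: methyl in place of hydrogen, four bonds along the chain from an aromatic carbon, gives a 2.1-fold lower number from compound 3 to compound 4 (0.32 log units; beyond the scatter) and so passes the scatter, which no exchange on the aromatic ring did. The step is modest and points towards higher toxicity in this test. Nothing measured here offers a reason for it.

As far as these compounds go, whether a still longer chain, such as pentyl, or an amine on this chain would extend the step remains open. So does whether the same lengthening acts alike on compound 1 and compound 2, which carry fluoro and methyl on the ring.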